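A few compounds are considered here, and "the series" means these few. Any claim that something is new, unique, unknown or untested is made for them only; others in the source may bear on it.

Measured so far:
- compound 1 `COc1ccc(-c2coc3cc(OCCCBr)ccc3c2=O)cc1`: 62600 nM
- compound 2 `COc1ccc(-c2coc3cc(OCCCSC(=S)N4CCN(Cc5ccccc5)CC4)ccc3c2=O)cc1`: 14900 nM

In a functional assay on PC-3 cells (Homo sapiens) for inhibition, read by MTT assay, with a stated time of 48 h (a lower number here means a stronger inhibitor, a higher number a weaker inhibitor), compound 1 holds the higher of the two numbers, so it is the weaker inhibitor of the pair, and its gap to compound 2 lies beyond the usual scatter. Compound 3 `COc1ccc(-c2coc3cc(OCCCCCBr)ccc3c2=O)cc1` departs from compound 1 by one change: 2-bromoethyl in place of bromo on a saturated chain carbon, three bonds along the chain from an oxygen on an aromatic ring. In words, this places 2-bromoethyl in place of bromo on a saturated chain carbon, three bonds along the chain from an oxygen on an aromatic ring. For the measured compounds named here, no measured pair isolates such a change, so the expectation rests on compound 1 at 62600 nM and on the modest nature of the change. The expected 1.4-fold lower number from compound 1 to compound 3 (0.14 log units; within the scatter) is small, leaning toward a lower number and probably not beyond the scatter. For compound 3 the estimated value is 45000 nM, with an expected range of 20000 nM to 90000 nM.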

Compound 3, half-maximal inhibitory concentration: 44800 nM
For compound 3 the middle estimate is 1.0-fold (0.00 log units) above the measured one; low and high end bracket the measured number.
By their numbers in this assay, from the lowest: compound 2; then compounds 3 and 1 (each within the scatter of the next).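

Setting 2-bromoethyl in place of bromo on this saturated chain carbon gives, in this assay, a 1.4-fold lower number from compound 1 to compound 3 (0.15 log units; within the scatter) and so leaves the two bromo-ended chains indistinguishable in this read-out. This is the first listed step that isolates a single change at this position, and it shows that this change in the length of the bromo-ended chain, on the shared core, does not move the number beyond the scatter. No measurement at hand bears on why this should be so.

The compounds shown leave open whether, in this assay on this same chain, an amine or a carboxylic acid in place of the bromine would give a different number. They also leave open whether a longer chain ending in bromine would stay within the scatter of compound 1.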